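Taking the Methyl off Compound 3

A few compounds are considered here, and "the series" means these few. Any claim that something is new, unique, unknown or untested is made for them only; others in the source may bear on it.

Compound 1 `CNc1cc(C)c(C(N)=O)cn1`: 1.11 h
Compound 2 `NC(=O)c1cnc2c(c1Cl)CCN2`: 0.45 h
Compound 3 `C[C@@H]1Cc2cc(C(N)=O)cnc2N1`: 1.31 h

All three values come from an ADME assay on the whole organism (Mus musculus, strain C57BL6/N) for metabolic stability, read by LC-MS, with a stated time of 24 h, at a dose of 10 mg/kg by the oral route; on this read-out higher numbers stand for a longer-lived compound and lower numbers for a shorter-lived compound. Compound 3 lies within the usual scatter of compound 1, so these two cannot be told apart on this read-out. Compound 2 has a lower number than compound 3, and that gap lies beyond the scatter.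

The next compound to be measured is compound 4 `NC(=O)c1cnc2c(c1)CCN2`. It has hydrogen in place of methyl on a saturated ring carbon of compound 3 (hydrogen in place of methyl on a saturated ring carbon). Going by the values given here, no pair of measured compounds differs in one place only, so the effect of this change on the half-life has not been observed directly. The nearest evidence is compound 2 at 0.45 h, which also has no methyl on that ring carbon but differs from compound 4 in another place as well. Compound 4 is therefore expected to fall between compound 2 and compound 3, and this rests on little data. The expected step is a 1.6-fold lower number from compound 3 to compound 4 (0.21 log units; within the scatter), towards a shorter-lived compound, but it is not expected to pass beyond the scatter. For compound 4 the estimated half-life is 0.8 h, with an expected range of 0.4 h to 1.5 h.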

Compound 4, half-life: 0.39 h
The estimate for compound 4 lay 2.1-fold (0.31 log units) above the measured number; measured number below the stated range.
By their numbers in this assay, from the lowest: compounds 4 and 2 (each within the scatter of the next); then compounds 1 and 3 (each within the scatter of the next).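

In this assay, hydrogen in place of methyl on a saturated ring carbon, next to the ring nitrogen, gives a 3.4-fold lower number from compound 3 to compound 4 (0.53 log units; beyond the scatter). Going by these compounds alone, this is the first direct reading of the change, and it shows that in this pair the half-life depends on the methyl at this place on the five-membered non-aromatic ring, since the step lies beyond the scatter. On the aromatic carbon, by contrast, hydrogen in place of chloro gives a 1.2-fold lower number from compound 2 to compound 4 (0.06 log units; within the scatter), which lies within the scatter, so compound 2 and compound 4 cannot be told apart on this read-out, and no measurement here accounts for the effect of the methyl.

The compounds shown leave open whether a larger group such as ethyl, or a different one such as hydroxyl or fluoro, on the same saturated ring carbon would match the methyl of compound 3 or go beyond it. They also leave open whether the mirror-image form of compound 3 would behave alike, and whether chloro on the aromatic carbon would still make no clear difference with the methyl present.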